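This account rests on a few compounds, and the source may have more. Where it says the series, first, only, none or still open, it means among the compounds named here.

The series shares one core, seen in compound 1 `COc1cc2ncnc(-n3nc(-c4cccnc4)nc3N)c2cc1OC`, and the numbers come from a physicochemical assay for solubility, in phosphate buffer, with a stated time of 18 h, at pH 7.4; on this read-out higher numbers stand for higher solubility and lower numbers for lower solubility. In this assay compound 1 gives 27000 nM. Compound 2 `COc1cc2ncnc(-n3nc(-c4ccc(Cl)cc4)nc3N)c2cc1OC` carries a different aromatic group on the shared core, and compound 2 gives 1000 nM. Among the measured compounds shown here, the single change that can be followed here is a 27-fold lower number from compound 1 to compound 2 (1.43 log units; beyond the scatter). Compound 3 `COc1cc2ncnc(-n3nc(-c4ccccn4)nc3N)c2cc1OCCCN1CC(C)OC(C)C1` stands second of the three numbers: compound 3 gives 8000 nM, which sits between the values of compound 1 and compound 2, beyond the scatter from each.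

Compound 4 `COc1cc2ncnc(-n3nc(-c4ccccn4)nc3N)c2cc1OCCCNC(=O)C(F)(F)F` is not yet measured. It differs from compound 3 in this way: ((trifluoromethyl)carbonyl)amino in place of 2,6-dimethylmorpholin-4-yl on a saturated chain carbon, three bonds along the chain from an oxygen on an aromatic ring. For the measured compounds named here, no measured step concerns this part of the molecule; the only measured step, from compound 1 to compound 2, changes an aromatic group on the other side of the shared core, so it offers no direct guide for the size or direction of this change. What remains is that the whole of the measured range in this assay spans from compound 2 to compound 1, and that compound 3 already lies inside it.

Because compound 3 gives 8000 nM, the estimate for compound 4 is 2500 nM, with a range from 500 nM to 10000 nM, which would be an expected step of a 3.2-fold lower number from compound 3 to compound 4 (0.51 log units; beyond the scatter).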

Compound 4, solubility: 1000 nM
For compound 4 the middle estimate is 2.5-fold (0.40 log units) above the measured one, and the stated range covers the measured number.
By their numbers in this assay, from the lowest: compounds 2 and 4 (each within the scatter of the next); then compound 3; then compound 1.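

In this assay, the exchange of 2,6-dimethylmorpholin-4-yl for ((trifluoromethyl)carbonyl)amino on a saturated chain carbon, three bonds along the chain from an oxygen on an aromatic ring, gives an 8.0-fold lower number from compound 3 to compound 4 (0.90 log units; beyond the scatter). Among the compounds shown here, this is the first measured step at this position, since the only earlier step lay on the other side of the shared core, and it shows that the group at this place can move the number by more than the usual scatter, here downward. No measurement shown here bears on why the number falls with this exchange.

The two groups differ at once in the six-membered ring, the fluorine atoms, the double bond and the hydrogen-bond donor, so the compounds shown leave open which of these differences goes with the lower number. Also open, going by these compounds, is how a simple amine such as dimethylamino, a carboxylic acid or a longer chain would read at the same place, and whether an open-chain group without fluorine would fall with compound 3 or with compound 4.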